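A carboxy group gives way to hydrogen

This account rests on a few compounds, and the source may have more. Where it says the series, first, only, none or still open, it means among the compounds named here.

Three compounds sharing a core have so far been taken to an ADME assay on L132 cells (Homo sapiens) for cytotoxicity, read by MTT assay, with a stated time of 72 h (on this read-out higher numbers stand for weaker inhibition and lower numbers for stronger inhibition), for a look at how much they harm cultured cells. Compound 1 (`COc1ccc(C2=C(c3cc(OC)c(OC)c(OC)c3)C(=O)CC2O[SiH2]C(C)(C)C)cc1`) gives > 100 ug/mL in this assay, which is a limit and not a number. Compound 2 (`COc1ccc(C2=C(c3cc(OC)c(OC)c(OC)c3)C(=O)CC2O)cc1O`) gives < 1 ug/mL in this assay, and this too is a limit and not a number. Compound 3 (`COc1cc(C2=C(c3ccc(OCC(=O)O)cc3)C(O)CC2=O)cc(OC)c1OC`) carries the entry "not determined" (no result reported) in this assay, so it has no place on the scale. Within the data shown here, the only readings around it are those of compound 1 and compound 2.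

Compound 4 (`COc1ccc(C2=C(c3cc(OC)c(OC)c(OC)c3)C(=O)CC2O)cc1`) differs from compound 3 in one place: hydrogen in place of carboxy on a saturated chain carbon bound to an oxygen on an aromatic ring, which turns carboxymethoxy into methoxy.

With no number for compound 3, no size or direction of step can be read from it in this assay. The expectation is only a placement, inside the wide span between the two limits and toward the stronger end, and it rests on very little. For compound 4, the half-maximal inhibitory concentration is estimated at 3 ug/mL, with an expected range from 0.4 ug/mL to 30 ug/mL for the result.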

Compound 4, half-maximal inhibitory concentration: 10 ug/mL
The estimate for compound 4 lay 3.3-fold (0.52 log units) below the measured number, within the range that was stated.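

The change from carboxymethoxy to methoxy cannot itself be read, as compound 3 has no result in this assay. Compound 4 does, however, put a size on two other single changes: hydrogen in place of hydroxy on an aromatic carbon (an at least 10-fold higher number from compound 2 to compound 4 (1.00 log units; beyond the scatter)) and a hydrogen atom in place of a group of 5 heavy atoms on an oxygen on a saturated carbon (an at least 10-fold lower number from compound 1 to compound 4 (1.00 log units; beyond the scatter)). Each of these steps starts from a limit of the assay and not a number, so each gives only a smallest size, and the true gaps may be wider.

The compounds shown do not tell how the number would move with an amide or a longer chain in place of the carboxy on the saturated chain carbon, and this position therefore has no reading yet. They also leave open what an ethoxy or a fluorine in place of the hydroxy on the aromatic carbon would do.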